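From a benzoate ester to a trifluoromethylbenzyl ether

The compounds below may be only part of what the source reports. "The series", "measured", "known", "first", "only" and "open" are said of these compounds alone.

Compound 1 `COc1cccc(C(=O)Oc2ccc3c(=O)c(-c4cc(OC)c(OC)cc4OC)coc3c2)c1` carries a (3-methoxyphenyl)carbonyl on an oxygen of the shared core. In a functional assay on A-375 cells (Homo sapiens) for antiproliferative activity, read by MTT assay, with a stated time of 24 h (a lower number here means a stronger inhibitor, a higher number a weaker inhibitor), compound 1 gives only a limit, > 10000 nM, and no number. Compound 2 `COc1cc(OC)c(-c2coc3cc(OCc4ccccc4C(F)(F)F)ccc3c2=O)cc1OC` likewise stops at a limit, > 10000 nM. Compound 3 `COc1cc(OC)c(-c2coc3cc(OCc4cccc(Cl)c4)ccc3c2=O)cc1OC` instead gives a measured value, 980 nM. Two of the three values therefore rest on (the limit of > 10000 nM in this assay, at which 2 of the 3 values shown sit).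

The unmeasured compound 4 `COc1cc(OC)c(-c2coc3cc(OCc4cccc(C(F)(F)F)c4)ccc3c2=O)cc1OC` differs from compound 1 as follows: 3-(trifluoromethyl)benzyl in place of (3-methoxyphenyl)carbonyl on an oxygen on an aromatic ring. The step from compound 1 that most resembles this one is an at least 10-fold lower number from compound 1 to compound 3 (1.00 log units; beyond the scatter), in which a benzyl ether also replaced the ester. The comparison an at least 10-fold lower number from compound 2 to compound 3 (1.00 log units; beyond the scatter) shows that the 3-chlorobenzyl of compound 3 reaches a measurable number where the 2-(trifluoromethyl)benzyl of compound 2 does not. Compound 4 bears a 3-(trifluoromethyl)benzyl, which in name resembles the group of compound 3 more than that of compound 2, so a step like that to compound 3 is expected, an at least 6.6-fold lower number from compound 1 to compound 4 (0.82 log units; beyond the scatter). Compound 4 is estimated at 1500 nM, between 400 nM and 8000 nM, with the limit seen for compound 1 and compound 2 as a real possibility.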

Compound 4, half-maximal inhibitory concentration: 1140 nM
Compound 4: the middle estimate sits 1.3-fold (0.12 log units) above what was measured; measured number inside the range.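

In this assay the result gives an at least 8.7-fold lower number from compound 2 to compound 4 (0.94 log units; beyond the scatter), with 3-(trifluoromethyl)benzyl in place of 2-(trifluoromethyl)benzyl, so the same substituent at a different place on the benzyl separates a measured number from a limit, which compound 2 and compound 3 could not show because their substituents also differ. Trifluoromethyl in place of chloro gives a 1.2-fold higher number from compound 3 to compound 4 (0.07 log units; within the scatter), so the two groups cannot be told apart here. A second benzyl ether gives an at least 8.7-fold lower number from compound 1 to compound 4 (0.94 log units; beyond the scatter), and this step and the one from compound 2 each have a limit at one end: the limit of > 10000 nM in this assay, at which 2 of the 4 values shown sit.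

The compounds shown leave open whether an amine or a carboxylic acid on the benzyl ring, or a longer chain on the oxygen on the aromatic ring, would keep a measurable number. They also do not tell whether a plain benzyl, with neither chloro nor trifluoromethyl, would do so.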